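From 4-methylphenyl to 4-nitrophenyl: compound 3 to compound 4

This account rests on a few compounds, and the source may have more. Where it says the series, first, only, none or still open, it means among the compounds named here.

Values so far in a physicochemical assay, with a stated time of 6 min (on this read-out lower numbers stand for stronger inhibition and higher numbers for weaker inhibition), by compound
compound 1 (`O=C(Nc1ccc(I)cc1)Nc1nc(-c2cc3ccccc3o2)cs1`) gives 62000 nM
compound 2 (`COc1ccc(NC(=O)Nc2nc(-c3cc4cc([N+](=O)[O-])ccc4o3)cs2)cc1`) gives 121000 nM
compound 3 (`Cc1ccc(NC(=O)Nc2nc(-c3cc4cc(Br)ccc4o3)cs2)cc1`) gives > 200000 nM (a limit)

Compound 3 stands only at a limit, > 200000 nM, and has no number. Compound 4 (`O=C(Nc1ccc([N+](=O)[O-])cc1)Nc1nc(-c2cc3cc(Br)ccc3o2)cs1`) carries nitro in place of methyl on an aromatic carbon, para to a large group (nitro in place of methyl on an aromatic carbon). Among the compounds with values here, no measured pair shows this change. Within the data shown here, compound 1 at 62000 nM and compound 2 at 121000 nM are the only numbers to anchor an expectation, and both differ from compound 4 in more than one place. In this assay a modest step towards stronger inhibition is expected, estimated as an at least 1.8-fold lower number from compound 3 to compound 4 (0.25 log units; that floor lies within the scatter), though it may stay within the scatter. Compound 4 is estimated at 110000 nM, with an expected range from 35000 nM to 200000 nM.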

Compound 4, half-maximal inhibitory concentration: > 200000 nM
Compound 4 was reported as a limit; the forecaster's own chance of this, stated with the estimate: 40%; middle value at least 1.8-fold (0.25 log units) away from the limit.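

In this assay compound 3 and compound 4 are both reported only as limits, so no step can be read between them: the limit of > 200000 nM in this assay, at which 2 of the 4 values shown sit.

The compounds shown leave open whether nitro in place of methyl changes inhibition at all.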